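The source may hold more compounds than are shown below. What is called first, only, known or untested is meant among the compounds shown, and "the series" means these compounds.

Compound 1 `C=C(Br)C(=O)Nc1cccc(-c2cn3c(-c4ccc(OC)cc4)csc3n2)c1` gives 860 nM; compound 2 `C=C(Br)C(=O)Nc1cccc(-c2cn3c(-c4ccccc4)csc3n2)c1` gives 3400 nM; compound 3 `C=C(Br)C(=O)Nc1cccc(-c2cn3nc(-c4ccccc4)sc3n2)c1` gives 1400 nM.

Among the compounds with values here, in a functional assay on HeLa cells (Homo sapiens) for inhibition, read by cell counting, with a stated time of 4 days (a higher number here means a weaker inhibitor, a lower number a stronger inhibitor), compound 2 stands with the highest number of the three, so it is the weakest inhibitor here; compound 3 lies lower, and the only single-point step measured, a 4.0-fold higher number from compound 1 to compound 2 (0.60 log units; beyond the scatter), shows what the methoxy group contributes. Compound 4 `Nc1cccc(-c2cn3c(-c4ccccc4)csc3n2)c1` keeps the whole core of compound 2 but is changed at one place: hydrogen in place of (1-bromoethenyl)carbonyl on a nitrogen on an aromatic ring. Within the data shown here, no measured step touches this part of the molecule, so the methoxy step gives no guide, and the expectation rests on the size of the change alone. A step of an 8.8-fold higher number from compound 2 to compound 4 (0.95 log units; beyond the scatter) toward weaker inhibition is expected. Compound 4 is therefore estimated at 30000 nM, within 5000 nM to 200000 nM.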

Compound 4, half-maximal inhibitory concentration: 60000 nM
Estimate against measurement, compound 4: 2.0-fold (0.30 log units) below; measured number inside the range.
By their numbers in this assay, from the lowest: compounds 1 and 3 (each within the scatter of the next); then compound 2; then compound 4.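

In this assay, within the data shown here, taking the (1-bromoethenyl)carbonyl off the nitrogen gives an 18-fold higher number from compound 2 to compound 4 (1.25 log units; beyond the scatter) and is the only step here that touches this position, since compounds 1, 2 and 3 all carry that group. Much of the inhibition seen with compound 2 therefore goes with this group, although compound 4, with its plain amino group, still gives 60000 nM and keeps a weak effect. Nothing measured here bears on the reason for this step.

Which part of the group matters stays open. An acetyl, acryloyl or chloroacetyl group on the same nitrogen would help separate the roles of the carbonyl, the double bond and the halogen.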